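The compounds below may be only part of what the source reports. "The series", "measured", "known", "first", "only" and "open" are said of these compounds alone.

Working notes on the indole series. Compound 1 `COC(=O)[C@@]1(C)CCC=C2[C@@H]1CC[C@@H](C)[C@]2(C)Cc1c[nH]c2ccc(Br)cc12` and compound 2 `COC(=O)[C@@]1(C)CCC=C2[C@@H]1CC[C@@H](C)[C@]2(C)Cc1c(C)[nH]c2ccccc12` share the same core and differ only in the substitution of the indole. In a functional assay on WiDr cells (Homo sapiens) for inhibition, read by sulforhodamine B assay, with a stated time of 48 h (a higher number here means a weaker inhibitor of growth, a lower number a stronger inhibitor of growth), compound 1 gives 20000 nM, and in the same assay compound 2 gives 19000 nM. Going by the values given here, the two numbers lie within the usual scatter of each other, so neither compound can be set apart from the other on these data; compound 2 is simply the one with the smaller number of the two. Compound 3 `COC(=O)[C@@]1(C)CCC=C2[C@@H]1CC[C@@H](C)[C@]2(C)Cc1c(C)[nH]c2ccc(Br)cc12` carries both substituents at once. Relative to compound 2 the change is bromo in place of hydrogen on an aromatic carbon. Among the compounds with values here, no measured pair in the set isolates this change, so the step can only be guessed from compound 1, whose value 20000 nM shows that the bromo alone does not move the number. The step from compound 2 to compound 3 is therefore expected to be small, a 1.1-fold lower number from compound 2 to compound 3 (0.02 log units; within the scatter), with no direction beyond the scatter. Compound 3 is estimated at 18000 nM in this assay, within a range from 8000 nM to 40000 nM.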

Compound 3, concentration for 50% growth inhibition: 15000 nM
For compound 3 the middle estimate is 1.2-fold (0.08 log units) above the measured one; measured number inside the range.
By their numbers in this assay, from the lowest: compounds 3, 2 and 1 (each within the scatter of the next).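

Bromo in place of hydrogen on an aromatic carbon can now be read directly in this assay: with the methyl present in both compounds, the step is a 1.3-fold lower number from compound 2 to compound 3 (0.10 log units; within the scatter) and stays within the scatter. The addition of the methyl can also be read, with the bromo present in both compounds: a 1.3-fold lower number from compound 1 to compound 3 (0.12 log units; within the scatter) likewise stays within the scatter, so neither substituent separates compound 3 from its partner. No supporting evidence accompanies these readings.

Whether any group at this position can give a step beyond the scatter remains open, since bromo is the only substituent shown there. An amine, a carboxylic acid or a longer chain in place of the bromo could test this, and the compounds shown give no indication of the outcome.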